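The source may report more compounds than this note shows. Statements on the series, on what has been measured and on what is new or still open speak of the compounds shown alone.

Measured compounds:
compound 1 `Oc1cccc(-c2cc(-c3ccccc3O)cc(-c3cccc(O)c3)n2)c1` — > 50000 nM
compound 2 `Oc1cccc(-c2cc(-c3cccc(O)c3)nc(-c3cccc(O)c3)c2)c1` — 4040 nM
compound 3 `Oc1ccc(-c2cc(-c3ccccc3O)cc(-c3ccccc3O)n2)cc1` — 360 nM

In a functional assay on DU-145 cells (Homo sapiens) for cytotoxicity, read by CCK-8 assay, with a stated time of 4 days (a lower number here means a stronger inhibitor, a higher number a weaker inhibitor), compound 1 reaches only a limit, > 50000 nM, and not a number; it sits at the limit of > 50000 nM in this assay, at which 1 of the 3 values shown sits. Compound 2 gives 4040 nM in this assay. The change from compound 1 to compound 2 is 3-hydroxyphenyl in place of 2-hydroxyphenyl on an aromatic carbon, and it made an at least 12-fold lower number from compound 1 to compound 2 (1.09 log units; beyond the scatter). Compound 3 gives 360 nM in this assay, the lowest of the two numbers shown. How the core of compound 3 differs from the core of compound 1 is not broken down here.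

Compound 4 `Oc1ccc(-c2cc(-c3cccc(O)c3)cc(-c3ccccc3O)n2)cc1` is not yet measured. It differs from compound 3 by 3-hydroxyphenyl in place of 2-hydroxyphenyl on an aromatic carbon. This is the same kind of change as from compound 1 to compound 2, but not the same: there the place was meta to two 3-hydroxyphenyl groups, here it is meta to a 2-hydroxyphenyl group and meta to a 4-hydroxyphenyl group. Resting on the direction of an at least 12-fold lower number from compound 1 to compound 2 (1.09 log units; beyond the scatter), compound 4 is expected to show a 2.4-fold lower number from compound 3 to compound 4 (0.38 log units; beyond the scatter) in this assay. Compound 4 is estimated at 150 nM in this assay, between 40 nM and 600 nM.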

Compound 4, half-maximal inhibitory concentration: > 50000 nM
Compound 4 gave a limit, no number (the forecaster's own chance of this, stated with the estimate: 3%); middle value at least 330-fold (2.52 log units) away from the limit.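

Compound 4 reaches only a limit in this assay, > 50000 nM, and not a number. The change from 2-hydroxyphenyl to 3-hydroxyphenyl gave an at least 130-fold higher number from compound 3 to compound 4 (2.14 log units; beyond the scatter), which runs opposite to the earlier step, so in this series neither its direction nor its size carries from one core to the other: the same change on two cores in this assay, an at least 12-fold lower number (1.09 log units; beyond the scatter) from compound 1 to compound 2 and an at least 130-fold higher number (2.14 log units; beyond the scatter) from compound 3 to compound 4, at least 1700-fold (3.23 log units) apart, beyond the scatter of two such steps This shows that the outcome of the change depends on the core that carries it, but it rests on only two pairs and does not show which feature of the cores is responsible, and each step has one end at a limit, so neither has an exact size: the limit of > 50000 nM in this assay, at which 2 of the 4 values shown sit.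

The compounds shown leave open whether the same reversal would appear on other cores carrying hydroxyphenyl groups. They also leave open how this assay would read if a methoxy group or an amine took the place of a hydroxyl group on these rings.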